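This account rests on a few compounds, and the source may have more. Where it says the series, first, only, none or still open, it means among the compounds named here.

Compound 1: `CN(Cc1cccc(F)c1)C(=O)CCCNC(=O)c1ccc(S(C)(=O)=O)c([N+](=O)[O-])c1` — > 60000 nM
Compound 2: `CN(Cc1ccccc1F)C(=O)CNC(=O)c1ccc(S(C)(=O)=O)c([N+](=O)[O-])c1` — > 60000 nM
Compound 3: `CC(C)N(C(=O)CNC(=O)c1ccc(S(C)(=O)=O)c([N+](=O)[O-])c1)C(C)C` — > 60000 nM

Of the compounds shown here, three sharing one core have been tested in an assay on isolated protein for inhibition of thyroid hormone receptor alpha (Homo sapiens), read by fluorescence polarization; on this read-out higher numbers stand for weaker inhibition and lower numbers for stronger inhibition. In this assay compound 1 gives only a limit, > 60000 nM, and not a number. Compound 2 likewise reaches only a limit, > 60000 nM. Compound 3 also stops at a limit, > 60000 nM. All three therefore sit at the same place, (the limit of > 60000 nM in this assay, at which 3 of the 3 values shown sit), so no ordering among them can be read, and nothing beyond the scatter separates any pair.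

Compound 4, `CS(=O)(=O)c1ccc(C(=O)NCCCC(=O)N2Cc3ccccc3C2)cc1[N+](=O)[O-]`, has not yet been measured. It differs from compound 1 in one place: a group of 9 heavy atoms (8 carbon, 1 nitrogen; one five-membered non-aromatic ring with 1 hetero atom, one six-membered aromatic ring of carbon only) in place of a group of 10 heavy atoms (8 carbon, 1 nitrogen, 1 fluorine; one six-membered aromatic ring of carbon only), on a carbonyl carbon.

For the measured compounds named here, no measured step is available for this change. Given that compound 1, compound 2 and compound 3 all rest at the limit of > 60000 nM in this assay, at which 3 of the 3 values shown sit, compound 4 is expected to show no step beyond the scatter, a number no higher from compound 1 to compound 4 (the limit leaves the size open), and most likely another limit. Compound 4 is estimated at 60000 nM, with a range from 20000 nM to 120000 nM.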

Compound 4, half-maximal inhibitory concentration: > 60000 nM
Compound 4: a limit, no number; the forecaster's own chance of this, stated with the estimate: 85%; the middle value sits exactly at the limit.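

In this assay compound 4 gives > 60000 nM, which is a limit and not a number. Compound 1 also rests at a limit, so no step can be read between compound 1 and compound 4, and all the compounds shown sit together: the limit of > 60000 nM in this assay, at which 4 of the 4 values shown sit. The compounds shown leave open which change to the shared core, if any, would give a measurable value in this assay.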